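A Shorter Chain on Compound 1

The compounds below may be only part of what the source reports. "The series", "measured", "known", "first", "only" and "open" are said of these compounds alone.

- Compound 1 `CN(C)CCCCCn1c2c(c3ccccc31)C(=O)c1c[n+]([O-])c3ccccc3c1C2=O`: 70 nM
- Compound 2 `CC1(C)OC[C@H](Cn2cc(Cn3c4c(c5ccccc53)C(=O)c3c[n+]([O-])c5ccccc5c3C4=O)nn2)O1`: 100 nM
- Compound 3 `CC1(C)OC[C@@H](Cn2cc(Cn3c4c(c5ccccc53)C(=O)c3c[n+]([O-])c5ccccc5c3C4=O)nn2)O1`: 6020 nM

All three compounds were tested in a toxicity assay on HEK-293T cells (Homo sapiens) for cytotoxicity, read by MTT assay, with a stated time of 72 h; on this read-out lower numbers stand for stronger inhibition and higher numbers for weaker inhibition. Compound 1 gives 70 nM, which lies within the usual scatter of compound 2 at 100 nM. Both values lie far from compound 3 at 6020 nM.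

The next compound to consider is compound 4 `CN(C)CCCCn1c2c(c3ccccc31)C(=O)c1c[n+]([O-])c3ccccc3c1C2=O`, which keeps the core of compound 1 and changes only the side chain: dimethylamino in place of (dimethylamino)methyl on a saturated chain carbon, four bonds along the chain from an aromatic nitrogen. The same difference can be read as 4-(dimethylamino)butyl to 3-(dimethylamino)propyl.

Among the compounds with values here, only one measured step is available, a 60-fold higher number from compound 2 to compound 3 (1.78 log units; beyond the scatter). This large step goes with the fact that compounds 2 and 3 differ only in the configuration as drawn. It involves no change in chain length, so it bears on the new change only as a warning that closely related compounds can differ widely in this assay. Within the data shown here, no measured step gives a size for this kind of change, so the best starting point is compound 1 at 70 nM, with a wide range around the estimate.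

The estimated change is small, a 1.3-fold higher number from compound 1 to compound 4 (0.11 log units; within the scatter), and no step beyond the scatter is expected. Compound 4 is expected at 90 nM, with an estimated range of 25 nM to 350 nM.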

Compound 4, half-maximal inhibitory concentration: 520 nM
For compound 4 the middle estimate is 5.8-fold (0.76 log units) below the measured one; the measured number lies above the stated range.
By their numbers in this assay, from the lowest: compounds 1 and 2 (each within the scatter of the next); then compound 4; then compound 3.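

Shortening the side chain from 4-(dimethylamino)butyl to 3-(dimethylamino)propyl, with the dimethylamino end and the core of compound 1 kept, gives a 7.4-fold higher number from compound 1 to compound 4 (0.87 log units; beyond the scatter) in this assay, so the length of the chain at this place, on a saturated chain carbon four bonds along the chain from an aromatic nitrogen, changes the read-out by more than the usual scatter. Before this result, the only measured step was a change of configuration, a 60-fold higher number from compound 2 to compound 3 (1.78 log units; beyond the scatter), and it said nothing about chain length; the new step is smaller, but it shows that a plain change in length is enough to weaken the effect in this assay. Nothing measured for these compounds explains why the shorter chain gives the higher number.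

One step between two chain lengths cannot yet show a trend: a 2-(dimethylamino)ethyl chain could continue the rise or break it, and a longer chain could go either way. On these data alone, whether the same step would appear with a diethylamino group at the chain end also remains open.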